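Nitro removal in a fused-ring series: note on compound 4

A few compounds are considered here, and "the series" means these few. Any claim that something is new, unique, unknown or untested is made for them only; others in the source may bear on it.

Measured in a functional assay on HepG2 cells (Homo sapiens) for antiproliferative activity, read by fluorescence and resazurin assay, with a stated time of 48 h; on this read-out higher numbers stand for weaker inhibition and lower numbers for stronger inhibition: compound 1 `O=C(N/N=C/c1ccncc1)c1cc2cc([N+](=O)[O-])ccc2oc1=O` gives 15800 nM; compound 2 `CCOc1ccc(NC(=O)c2cc3cc([N+](=O)[O-])ccc3oc2=O)cc1` gives 28300 nM; compound 3 `CCOc1ccc(NC(=O)c2cc3ccccc3oc2=O)cc1` gives 10400 nM.

Compound 3 differs from compound 2 by hydrogen in place of nitro on an aromatic carbon, and this gave a 2.7-fold lower number from compound 2 to compound 3 (0.43 log units; beyond the scatter). The values of compound 1 and compound 3, and of compound 1 and compound 2, lie within the scatter of each other. The difference between the core of compound 1 and the core of compound 2 is not broken down here.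

Compound 4 `O=C(N/N=C/c1ccncc1)c1cc2ccccc2oc1=O` carries the same change on compound 1: hydrogen in place of nitro on an aromatic carbon. Only one earlier case of this change is at hand, so the expectation rests on it alone. The step from compound 1 to compound 4 is expected to be a 2.6-fold lower number from compound 1 to compound 4 (0.42 log units; beyond the scatter) in this assay because the same change gave a 2.7-fold lower number from compound 2 to compound 3 (0.43 log units; beyond the scatter). Compound 4 is thus estimated at 6000 nM, between 2500 nM and 15000 nM.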

Compound 4, half-maximal inhibitory concentration: 17200 nM
Compound 4: middle estimate off by 2.9-fold (0.46 log units), on the low side, outside the stated range (above it).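

Replacing nitro with hydrogen on the core of compound 1 gave a 1.1-fold higher number from compound 1 to compound 4 (0.04 log units; within the scatter) in this assay. The change therefore does not carry over as a fixed step between these two cores: the same change on two cores in this assay, a 2.7-fold lower number (0.43 log units; beyond the scatter) from compound 2 to compound 3 and a 1.1-fold higher number (0.04 log units; within the scatter) from compound 1 to compound 4, 3.0-fold (0.47 log units) apart, beyond the scatter of two such steps This shows that a step read on one core cannot simply be transferred to the other in this series, but two cases do not show which part of the cores sets the difference or how the change behaves on any further core.

Still open, on these data alone, is whether an amine or a carboxylic acid in place of nitro would follow the step on one core, the other, or neither. Also open, as far as these compounds go, is whether either group would give the same step on both cores.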